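A few compounds are considered here, and "the series" means these few. Any claim that something is new, unique, unknown or untested is made for them only; others in the source may bear on it.

Measured compounds, read in a functional assay on the whole organism (strain Swiss) with Mus musculus as the target, in the maximal electroshock model, with a stated time of 2 h, at a dose of 100 mg/kg by the intraperitoneal route; a higher number here means a stronger effect of the compound at the dose given, a lower number a weaker effect:

compound 1, `CC(C(=O)N1CCN(c2ccccc2C(F)(F)F)CC1)N1C(=O)CCC1=O`: 0%
compound 2, `COc1cccc(N2CCN(C(=O)C(C)N3C(=O)CCC3=O)CC2)c1`: 0%
compound 3, `CCC(C(=O)N1CCN(c2ccccc2)CC1)N1C(=O)CCC1=O`: 0%

All three measured compounds share the same core and differ only in the group on the ring nitrogen of the six-membered non-aromatic ring and in the small alkyl substituent next to the amide carbonyl. In this assay compound 2 gives 0%, and compound 1 and compound 3 return the same figure at the digits shown; the three values lie within the scatter of one another, so no order among them can be read from these numbers. Within the data shown here, no step between measured compounds has been worked out, and nothing in the set so far separates one aryl substituent from another in this read-out.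

Compound 4, `CC(C(=O)N1CCN(c2ccc(F)cc2)CC1)N1C(=O)CCC1=O`, has not yet been measured in this assay. It differs from compound 2 in one place:

4-fluorophenyl in place of 3-methoxyphenyl on an amine nitrogen in a ring

Because compound 2 gives 0% and compound 1 and compound 3 give the same figure with different aryl groups in the same place, no step beyond the scatter is expected for no change at the digits printed from compound 2 to compound 4 (within the scatter). For compound 4 the expected value in this assay is 0%, with a range of 0% to 10%.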

Compound 4, a percentage reported as activity, at one dose (the size of the read-out at that dose, not a potency): 0%
Compound 4: middle estimate and measured number agree at the digits printed, and the stated range covers the measured number.
By their numbers in this assay, from the lowest: compounds 1, 2, 3 and 4 (each within the scatter of the next).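

In this assay the series now has its first step at a single place, on an amine nitrogen in a ring: 4-fluorophenyl in place of 3-methoxyphenyl gives no change at the digits printed from compound 2 to compound 4 (within the scatter) and leaves the shared core otherwise unchanged. This exchange swaps a group with one hydrogen-bond acceptor for a group with none, and the read-out does not separate the two, but both ends of the step lie at the same zero reading, so it gives no measure of how much this position can contribute. No measurement at hand bears on the reason for this result.

The compounds shown leave open whether a different group on this nitrogen, such as benzyl, 4-chlorophenyl or a phenyl carrying a carboxylic acid, would lift the reading above that of compound 4 at 0% in this model. Also open, going by these compounds, is whether a longer chain in place of the methyl on the carbon bearing the amide carbonyl, taken as a one-place change from compound 4, would move the read-out in this assay at all.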